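From a 2-iodophenyl thiourea to a pyridin-3-yl thiourea

The source may hold more compounds than are shown below. What is called first, only, known or untested is meant among the compounds shown, and "the series" means these compounds.

Three compounds share one core and differ only in the group on the ring amine nitrogen. Compound 1 `Cc1ccccc1CN1CCc2c(sc(NC(=O)c3ccccc3Cl)c2C(N)=O)C1` sits at a limit of the assay, giving > 50000 nM in a functional assay on MKN-74 cells (Homo sapiens) for antiproliferative activity, with a stated time of 24 h; a lower number here means a stronger inhibitor, a higher number a weaker inhibitor; this is a limit and not a number. Compound 2 `NC(=O)c1c(NC(=O)c2ccccc2Cl)sc2c1CCN(Cc1ccccc1F)C2` gives 12900 nM in this assay, a change of an at least 3.8-fold lower number from compound 1 to compound 2 (0.58 log units; beyond the scatter). Compound 3 `NC(=O)c1c(NC(=O)c2ccccc2Cl)sc2c1CCN(C(=S)Nc1ccccc1I)C2` gives 2630 nM in this assay, with steps of an at least 19-fold lower number from compound 1 to compound 3 (1.27 log units; beyond the scatter) and a 4.9-fold lower number from compound 2 to compound 3 (0.69 log units; beyond the scatter). Of the two numbers shown, compound 3 has the lowest, so it is the strongest inhibitor measured here.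

Compound 4 `NC(=O)c1c(NC(=O)c2ccccc2Cl)sc2c1CCN(C(=S)Nc1cccnc1)C2` keeps the thiourea and changes its aryl group: pyridin-3-yl in place of 2-iodophenyl on an amide-type nitrogen. Among the measured compounds shown here, no measured step alters this part; the steps from compound 1 and compound 2 to compound 3 exchange the whole group on the ring amine nitrogen, so they show only that this position is sensitive, not how the pyridin-3-yl group will read. A modest move in either direction is therefore plausible, with a weakening judged somewhat more likely, so compound 4 is expected to give about 5000 nM in this assay, a step of a 1.9-fold higher number from compound 3 to compound 4 (0.28 log units; within the scatter), within the range 1500 nM to 20000 nM.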

Compound 4, half-maximal inhibitory concentration: 38600 nM
Compound 4: middle estimate off by 7.7-fold (0.89 log units), on the low side; the whole stated range lies below it.
By their numbers in this assay, from the lowest: compound 3; then compound 2; then compound 4. At a limit, above all of these: compound 1.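

The pyridin-3-yl compound shows that the aryl group on the thiourea matters strongly on its own: with the thiourea kept, pyridin-3-yl in place of 2-iodophenyl on an amide-type nitrogen gives a 15-fold higher number from compound 3 to compound 4 (1.17 log units; beyond the scatter) in this assay. A thiourea alone therefore does not secure a low number, as exchanging the fluorophenylmethyl group on the ring amine nitrogen for the pyridin-3-yl thiourea gives a 3.0-fold higher number from compound 2 to compound 4 (0.48 log units; beyond the scatter). The change of an at least 1.2-fold lower number from compound 1 to compound 4 (0.11 log units; that floor lies within the scatter) rests on a limit of the assay and not on a number: the limit of > 50000 nM in this assay, at which 1 of the 4 values shown sits.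

Iodine leaves and a ring nitrogen enters in the same step, and the compounds shown cannot separate the share of each in the large change. As far as these compounds go, how a plain phenyl, a bromophenyl or an aminophenyl group on the same thiourea nitrogen would read stays open, and any of these would help to tell whether losing the iodine or gaining the ring nitrogen weighs more.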